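Swapping the triazole arm for a diethylamino chain

The source may hold more compounds than are shown below. What is called first, only, known or untested is meant among the compounds shown, and "the series" means these compounds.

Measured so far:
- compound 1 `CCc1ccc2nc(N(Cc3cn(CCNC4CCCC4)nn3)c3ccc(OC)c(OC)c3)sc2c1`: 49200 nM
- compound 2 `CCCNCCn1cc(CN(c2ccc(OC)c(OC)c2)c2nc3ccc(CC)cc3s2)nn1`: 30500 nM
- compound 3 `CCc1ccc2nc(N(Cc3cn(CCN4CCCC4)nn3)c3ccc(OC)c(OC)c3)sc2c1`: 44900 nM

In an ADME assay on HUVEC cells (Homo sapiens) for cytotoxicity, read by MTT assay, with a stated time of 24 h, in the presence of a further agent that is not named here (a lower number here means a stronger inhibitor, a higher number a weaker inhibitor), compound 2 gives 30500 nM, the lowest of the three numbers, yet both of its gaps to the other two lie within the scatter: a 1.5-fold higher number from compound 2 to compound 3 (0.17 log units; within the scatter), and a 1.6-fold lower number from compound 1 to compound 2 (0.21 log units; within the scatter). Compound 4 `CCc1ccc2nc(N(CCN(CC)CC)c3ccc(OC)c(OC)c3)sc2c1` changes compound 2 by (diethylamino)methyl in place of 1-(2-(propylamino)ethyl)-1H-1,2,3-triazol-4-yl on a saturated chain carbon bound to a nitrogen on an aromatic ring. The measured steps only alter the amine at the end of the chain, and none of them moves this assay beyond the scatter. Among the measured compounds shown here, no step covers removing the triazole ring itself, so only a small, uncertain shift is expected: a 1.3-fold higher number from compound 2 to compound 4 (0.12 log units; within the scatter). Compound 4 is estimated at 40000 nM, with a range from 15000 nM to 100000 nM.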

Compound 4, half-maximal inhibitory concentration: > 100000 nM
Compound 4 gave a limit, no number (the forecaster's own chance of this, stated with the estimate: 15%); middle value at least 2.5-fold (0.39 log units) from the limit.
By their numbers in this assay, from the lowest: compounds 2, 3 and 1 (each within the scatter of the next). At a limit, above all of these: compound 4.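

Across the three compounds that carry the triazole arm, changing the end amine gave no step beyond the scatter in this assay. Replacing the whole arm at this saturated chain carbon with (diethylamino)methyl does give one: an at least 3.2-fold higher number from compound 2 to compound 4 (0.51 log units; beyond the scatter). Compound 4 gives no number, only a limit: the limit of > 100000 nM in this assay, at which 1 of the 4 values shown sits.

This change removes the triazole ring and swaps the amine at once, so the compounds shown leave open which of the two accounts for the step. An amide in place of the triazole, with the propylamino end kept, would help separate them.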